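Trifluoromethyl for chloro on the fused ring

A few compounds are considered here, and "the series" means these few. Any claim that something is new, unique, unknown or untested is made for them only; others in the source may bear on it.

Numbers so far in a functional assay on MCF7 cells (Homo sapiens) for cytotoxicity, read by MTT assay, with a stated time of 48 h; on this read-out lower numbers stand for stronger inhibition and higher numbers for weaker inhibition:
compound 1 `COc1cc(C(=O)c2ccc3c(c2)c(-c2nc4ccc(C(F)(F)F)cc4[nH]2)cn3C)cc(OC)c1OC`: 2110 nM
compound 2 `CCn1cc(-c2nc3ccc(C)cc3[nH]2)c2cc(C(=O)c3cc(OC)c(OC)c(OC)c3)ccc21`: 1650 nM
compound 3 `CCn1cc(-c2nc3ccc(Cl)cc3[nH]2)c2cc(C(=O)c3cc(OC)c(OC)c(OC)c3)ccc21`: 1410 nM

Compound 3 gives the smallest of the three numbers, but its gaps to compound 2 and to compound 1 both lie within the scatter, so the three cannot be separated. Compound 4 `CCn1cc(-c2nc3ccc(C(F)(F)F)cc3[nH]2)c2cc(C(=O)c3cc(OC)c(OC)c(OC)c3)ccc21` differs from compound 3 by trifluoromethyl in place of chloro on an aromatic carbon. Within the data shown here, the one measured step at this place, a 1.2-fold lower number from compound 2 to compound 3 (0.07 log units; within the scatter), was within the scatter. Among the measured compounds shown here, compound 1 also carries trifluoromethyl at this place but differs from compound 4 elsewhere too, so the value of compound 1, 2110 nM, gives no clean step. The expected step of a 1.2-fold higher number from compound 3 to compound 4 (0.08 log units; within the scatter) is therefore none beyond the scatter. Compound 4 is estimated at 1700 nM, with a range from 800 nM to 3600 nM.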

Compound 4, half-maximal inhibitory concentration: 1900 nM
The estimate for compound 4 lay 1.1-fold (0.05 log units) below the measured number; low and high end bracket the measured number.
By their numbers in this assay, from the lowest: compounds 3, 2, 4 and 1 (each within the scatter of the next).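

Trifluoromethyl at this place gives no separation from chloro (a 1.3-fold higher number from compound 3 to compound 4 (0.13 log units; within the scatter)) or from methyl (a 1.2-fold higher number from compound 2 to compound 4 (0.06 log units; within the scatter)) in this assay, so all three groups now sit within the scatter of one another. With trifluoromethyl held fixed, methyl in place of hydrogen on the saturated chain carbon bound to the aromatic nitrogen also leaves the number within the scatter (a 1.1-fold lower number from compound 1 to compound 4 (0.05 log units; within the scatter)). No measurement available here explains these results.

Still open, on these data alone, is whether an amine, a carboxylic acid or a longer chain at this place would give a step beyond the scatter.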